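Fluoro Addition on Two Cores in a Rat Inhibition Series

A few compounds are considered here, and "the series" means these few. Any claim that something is new, unique, unknown or untested is made for them only; others in the source may bear on it.

Compound 2 `O=c1c(-c2nn[nH]n2)c[nH]c2c(F)cccc12` and compound 1 `O=c1c(-c2nn[nH]n2)c[nH]c2c(F)ccc(F)c12` share one core. In a functional assay on the whole organism (strain Sprague-Dawley) for inhibition, with Rattus norvegicus as the target (on this read-out higher numbers stand for an effect only at larger amounts of compound and lower numbers for an effect already at smaller amounts), compound 2 gives 0.625 mg/kg. Compound 1 gives > 0.156 mg/kg, a limit of this assay and not a number. The step that the limit leaves unreadable from compound 2 to compound 1 cannot be sized because the limit of > 0.156 mg/kg in this assay, at which 1 of the 3 values shown sits, covers its end.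

Compound 3 `O=C(O)c1cnc2c(F)cccc2c1` has another core; the difference between the two cores is not broken down here. In this assay compound 3 gives > 25 mg/kg, again a limit rather than a number, as the limit of > 25 mg/kg in this assay, at which 1 of the 3 values shown sits, marks.

Compound 4 `O=C(O)c1cnc2c(F)cc(F)cc2c1` is to be measured in this assay. It differs from compound 3 by fluoro in place of hydrogen on an aromatic carbon, the same kind of change as fluoro in place of hydrogen on an aromatic carbon, though here the place is meta to a fluoro group, meta to a fused ring and para to a fused ring, whereas in compound 1 it is ortho to a fused ring, meta to a fused ring and para to a fluoro group. The step of a number no higher from compound 3 to compound 4 (the limit leaves the size open) is expected to be small, resting only on compound 3 sitting at > 25 mg/kg. Compound 4 is expected near 25 mg/kg, between 6 mg/kg and 100 mg/kg, most likely reported as a limit.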

Compound 4, minimum effective dose: 25 mg/kg
Beside the measured number, compound 4's estimate shows no gap at the digits printed, within the range that was stated.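

In this assay, fluoro in place of hydrogen on an aromatic carbon gives the step of a number no higher from compound 3 to compound 4 (the limit leaves the size open), and on the other core the same kind of change gives the step that the limit leaves unreadable from compound 2 to compound 1. Neither step can be read for size, so the change is seen on both cores, but nothing shows that its effect carries from one core to the other or that it differs between them. The end of the step on the core of compound 3 is a limit of the assay and not a number: the limit of > 25 mg/kg in this assay, at which 1 of the 4 values shown sits.

Going by these compounds, what chloro or methoxy in place of that fluoro would give on either core remains open. So does the effect of an amide in place of the carboxylic acid of compound 4.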